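The source may report more compounds than this note shows. Statements on the series, on what has been measured and on what is new or still open speak of the compounds shown alone.

Measured in a functional assay on MCF7 cells (Homo sapiens) for inhibition, read by MTT assay, with a stated time of 96 h; a lower number here means a stronger inhibitor of growth, a higher number a weaker inhibitor of growth:
- compound 1 `O=C(OCc1ccccc1)SCCCCCCNC(=O)c1cc(-c2ccncc2)n[nH]1`: 8370 nM
- compound 2 `CC(C)C(=O)SCCCCCCNC(=O)c1cc(-c2ccncc2)n[nH]1`: 15200 nM
- compound 3 `CCCC(=O)SCCCCCCNC(=O)c1cc(-c2ccncc2)n[nH]1`: 12100 nM

These three values lie within the scatter of one another, so compound 3, at 12100 nM, cannot be separated from the other two. The unmeasured compound 4 `CC(=O)SCCCCCCNC(=O)c1cc(-c2ccncc2)n[nH]1` carries acetyl where compound 3 carries propylcarbonyl. The change is hydrogen in place of ethyl on a saturated chain carbon bound to a carbonyl carbon.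

Among the measured compounds shown here, no measured step makes exactly this change. The nearest evidence comes from other replacements on the same carbonyl carbon: a 1.3-fold lower number from compound 2 to compound 3 (0.10 log units; within the scatter), a 1.4-fold higher number from compound 1 to compound 3 (0.16 log units; within the scatter) and a 1.8-fold higher number from compound 1 to compound 2 (0.26 log units; within the scatter). All three stay within the scatter, including the two that remove benzyloxy. In this assay, therefore, no change beyond the scatter is expected, and no direction can be argued from these data.

The expected step is a 1.1-fold lower number from compound 3 to compound 4 (0.04 log units; within the scatter).

Compound 4 is estimated at 11000 nM, with an expected range of 5500 nM to 23000 nM.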

Compound 4, concentration for 50% growth inhibition: 24900 nM
Compound 4: middle estimate off by 2.3-fold (0.35 log units), on the low side; measured number outside the range, above it.
By their numbers in this assay, from the lowest: compounds 1, 3, 2 and 4 (each within the scatter of the next, the first and the last beyond it).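

In this assay, among the compounds shown here, hydrogen in place of ethyl gives the first step between the two straight-chain groups on this carbonyl carbon, and it lies beyond the scatter, though only modestly (a 2.1-fold higher number from compound 3 to compound 4 (0.31 log units; beyond the scatter)). Acetyl also separates modestly from benzyloxy (a 3.0-fold higher number from compound 1 to compound 4 (0.47 log units; beyond the scatter)) but stays within the scatter of the isopropyl compound (a 1.6-fold higher number from compound 2 to compound 4 (0.21 log units; within the scatter)), so the position shows some sensitivity, with compound 2 blurring any simple ordering by group size. The data shown offer no measured basis for explaining this shift.

Still open, going by these compounds, is whether a longer chain, such as hexyl, or an amine on the same carbonyl carbon would move the number beyond the scatter of compound 1. The compounds shown also leave open whether the modest separation of compound 4 from compounds 1 and 3 would hold across further groups at this position.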